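Thiosemicarbazone series notes: from compound 3 to compound 4

The source may report more compounds than this note shows. Statements on the series, on what has been measured and on what is new or still open speak of the compounds shown alone.

Compound 1 `CC1=CC[C@H](C(C)(C)N=C=S)CC1`, compound 2 `CC1=CC[C@H](C(C)(C)NC(=S)N/N=C/c2ccc(N(C)C)cc2)CC1` and compound 3 `CC1=CC[C@H](C(C)(C)NC(=S)N/N=C/c2ccc(F)cc2)CC1` share one core. In a functional assay on HT-29 cells (Homo sapiens) for inhibition, read by sulforhodamine B assay, with a stated time of 48 h (a lower number here means a stronger inhibitor of growth, a higher number a weaker inhibitor of growth), compound 1 gives only a limit, > 100000 nM. In this assay compound 2 likewise gives only a limit, > 100000 nM. In this assay compound 3 also gives only a limit, > 100000 nM. The step from compound 2 to compound 3, a step that the two limits leave unreadable from compound 2 to compound 3, cannot be read because of the limit of > 100000 nM in this assay, at which 3 of the 3 values shown sit. Compound 4 `CC1=CC[C@H](C(C)(C)NC(=S)N/N=C/c2cccs2)CC1` differs from compound 3 by thiophen-2-yl in place of 4-fluorophenyl on a carbon with a double bond to nitrogen. Going by the values given here, no measured step bears on this change, and every value so far sits at the limit, so neither size nor direction can be taken from the series. Compound 4 is expected to remain at the limit in this assay, the step from compound 3 to compound 4 being estimated as a step that the limit leaves unreadable from compound 3 to compound 4. The estimate for compound 4 is 150000 nM, from 50000 nM to 500000 nM.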

Compound 4, concentration for total growth inhibition: 57800 nM
Compound 4: middle estimate off by 2.6-fold (0.41 log units), on the high side; the measured number falls inside the stated range.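

Thiophen-2-yl in place of 4-fluorophenyl on a carbon with a double bond to nitrogen gives the first reading in the series that is a number rather than a limit. In this assay this change gives an at least 1.7-fold lower number from compound 3 to compound 4 (0.23 log units; that floor lies within the scatter). Only that floor can be read, and the other steps cannot be read at all, because the remaining values are limits: the limit of > 100000 nM in this assay, at which 3 of the 4 values shown sit.

Still open, as far as these compounds go, is the true size of the step, since its floor does not clear the scatter. From the compounds shown here alone, how furan-2-yl or pyridin-2-yl would read on the same carbon also remains open.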